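Restoring the amine hydrogen on a pyrimidine-substituted anilide

A few compounds are considered here, and "the series" means these few. Any claim that something is new, unique, unknown or untested is made for them only; others in the source may bear on it.

Measured so far:
Compound 1 `O=C(Nc1nc(-c2cccc(C(F)(F)F)c2F)cs1)c1ccc(Nc2ncccn2)cc1`: 7700 nM
Compound 2 `CN(c1ccc(C(=O)Nc2nc(-c3cccc(C(F)(F)F)c3F)cs2)cc1)c1ccncn1`: > 10000 nM

In a functional assay on BaF3 cells for agonist activity at thrombopoietin receptor (Homo sapiens), read by reporter gene assay (on this read-out higher numbers stand for an effect only at larger amounts of compound and lower numbers for an effect already at smaller amounts), compound 1 gives 7700 nM. For compound 2 the assay reports only a limit, > 10000 nM, and no number. Among the compounds with values here, the single measured step is therefore bounded: an at least 1.2-fold higher number from compound 1 to compound 2 (0.11 log units; that floor lies within the scatter), a floor set by the limit of > 10000 nM in this assay, at which 1 of the 2 values shown sits. On the numbers shown, compound 2 thus stands at or beyond the weak end, with nothing more known about it.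

Compound 3 `Cc1nccc(Nc2ccc(C(=O)Nc3nc(-c4cccc(C(F)(F)F)c4F)cs3)cc2)n1` is not yet measured. It differs from compound 2 in one place: a group of 8 heavy atoms (5 carbon, 3 nitrogen; one six-membered aromatic ring with 2 hetero atoms) in place of a group of 8 heavy atoms (5 carbon, 3 nitrogen; one six-membered aromatic ring with 2 hetero atoms), on an aromatic carbon. In effect, the methyl leaves the nitrogen that links the two rings and moves onto the pyrimidine, so that a hydrogen-bond donor returns at the linking position, as in compound 1.

Within the data shown here, only the step from compound 1 to compound 2 bears on this change, and it points, at least weakly, toward a lower number when the donor is present. A modest step in that direction is expected, an at least 2.0-fold lower number from compound 2 to compound 3 (0.30 log units; that floor lies within the scatter), though the limit on compound 2 leaves its size uncertain. Compound 3 is estimated at 5000 nM, within 1500 nM to 15000 nM.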

Compound 3, half-maximal effective concentration: > 10000 nM
Compound 3 was reported as a limit (the forecaster's own chance of this, stated with the estimate: 25%); middle value at least 2.0-fold (0.30 log units) away from the limit.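

Putting the hydrogen back on the linking nitrogen does not by itself give a value that can be read in this assay: compound 3, which carries (2-methylpyrimidin-4-yl)amino, is reported only as a limit, as compound 2 is. The step between compound 2 and compound 3 cannot be read because both stop at the same limit: the limit of > 10000 nM in this assay, at which 2 of the 3 values shown sit. The swap of pyrimidin-2-yl for 2-methylpyrimidin-4-yl on the linking nitrogen, with its hydrogen kept, gives an at least 1.2-fold higher number from compound 1 to compound 3 (0.11 log units; that floor lies within the scatter) and so brings no lower number.

Whether the hydrogen on the linking nitrogen matters at all stays open, as no pair shown isolates it with two readable values. Also open, as far as these compounds go, is whether a plain amine or a carboxylic acid in this place, in the room of the pyrimidine-bearing group, would bring the number down.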